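The source may hold more compounds than are shown below. What is called first, only, known or untested is meant among the compounds shown, and "the series" means these compounds.

Measured so far in an assay on PEO1 cells for inhibition of Retinaldehyde dehydrogenase 3 (Homo sapiens), read by flow cytometry, with a stated time of 30 min, tested at 1 uM; a higher number here means more inhibition at the concentration tested (going by the name of the read-out), a lower number less inhibition:
compound 1, `C[C@@H](Sc1nc2c(cnn2C)c(=O)n1-c1ccccc1)c1ccccc1`: "active" (no number reported); 71% (2 entries)
compound 2, `CC(Sc1nc2c(cnn2C)c(=O)n1-c1ccccc1)c1cccnc1`: 95%
compound 3, `CC(Sc1nc2c(cnn2C)c(=O)n1-c1ccccc1)c1cccc(O)c1`: 61%

In this assay compound 3 gives 61%, the lowest of the two single numbers. Compound 2 gives 95%, and compound 1 has several entries, (the several entries of compound 1 in this assay, "active" (no number reported); 71% (2 entries)). Among the compounds with values here, the one measured step, a number 34 percentage points lower from compound 2 to compound 3 (beyond the scatter), shows that exchanging the ring on that chain carbon can move the read-out by a large amount.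

Compound 4, `Cn1ncc2c(=O)n(-c3ccccc3)c(SCc3cccc(F)c3)nc21`, differs from compound 3 at the sulfur: a group of 8 heavy atoms (7 carbon, 1 fluorine; one six-membered aromatic ring of carbon only) in place of a group of 9 heavy atoms (8 carbon, 1 oxygen; one six-membered aromatic ring of carbon only), on a sulfur. In words, a group of 8 heavy atoms (7 carbon, 1 fluorine; one six-membered aromatic ring of carbon only) replaces a group of 9 heavy atoms (8 carbon, 1 oxygen; one six-membered aromatic ring of carbon only). Within the data shown here, the step from compound 2 to compound 3 is the only measured change near this place, and it was large; it does not tell the direction for a 3-fluorobenzyl group, so a step of moderate size in either direction would fit, and the values of compound 1 and compound 3 suggest a number in the middle of the seen range. Compound 4 is therefore expected to give about 68%, within 40% to 92%. The expected step, a number 7 percentage points higher from compound 3 to compound 4 (within the scatter), is a modest rise.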

Compound 4, a percentage reported as inhibition, at one concentration (the size of the read-out at that concentration, not a potency) in the Retinaldehyde dehydrogenase 3 assay: 3%
Compound 4: the middle estimate sits 65 percentage points above what was measured; the measured number lies below the stated range.
By their numbers in the Retinaldehyde dehydrogenase 3 assay, from the lowest: compound 4; then compound 3; then compound 2.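

Within the data shown here, exchanging the whole group on the sulfur can almost erase the read-out in the Retinaldehyde dehydrogenase 3 assay: with 3-fluorobenzyl there is a number 58 percentage points lower from compound 3 to compound 4 (beyond the scatter) and also a number 92 percentage points lower from compound 2 to compound 4 (beyond the scatter) in the same assay, both larger than the one step seen before. So this position does not merely tune the read-out, and a group with the same kind of carbon-only aromatic ring as compound 3 can still give almost nothing. The same exchange also goes with a large loss in a physicochemical assay for solubility, using the shake flask method, in phosphate buffer, with a stated time of 24 h, at pH 7.4; on this read-out higher numbers stand for higher solubility and lower numbers for lower solubility: the measured solubility of compound 3, 21000 nM, and of compound 4, < 700 nM, an at least 30-fold lower number (1.47 log units; beyond the scatter)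
In the physicochemical assay compound 3 gives 21000 nM.
For compound 4 in the physicochemical assay the value < 700 nM is a limit of the assay and not a number.

The change from compound 3 to compound 4 alters the ring substituent and the chain carbon together, so the compounds shown cannot say which of the two carries the drop, nor whether the drop is linked to the solubility result. A 1-(3-fluorophenyl)ethyl group on the sulfur would separate the two, and a ring bearing an amine or a carboxylic acid remains an open question at this position.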